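The source may hold more compounds than are shown below. What is called first, only, known or untested is meant among the compounds shown, and "the series" means these compounds.

Working notes on the series.

Four compounds, two cores, one chain. Compound 1 `O=C(NCCCCc1ccccc1)n1nnc2ccccc21` and compound 3 `CCCCCCNC(=O)n1nnc2ccccc21` carry the first core; compound 2 `O=C(NCCCCc1ccccc1)N1C(=O)c2ccccc2C1=O` and compound 4 `CCCCCCNC(=O)N1C(=O)c2ccccc2C1=O` carry the second. How the core of compound 2 differs from the core of compound 1 is not broken down here.

In a physicochemical assay for metabolic stability, read by HPLC, at pH 4.5, tested at 10 uM (a higher number here means that the compound lasts longer, a lower number that the compound disappears faster), compound 1 gives > 2 h, which is a limit of the assay and not a number. In this assay compound 3 gives > 2 h, again a limit. In this assay compound 2 gives > 2 h, also a limit.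

The change from compound 1 to compound 3 is ethyl in place of phenyl on a saturated chain carbon, four bonds along the chain from an amide-type nitrogen. The step it made is a step that the two limits leave unreadable from compound 1 to compound 3, unreadable because of the limit of > 2 h in this assay, at which 3 of the 3 values shown sit.

The change from compound 2 to compound 4 is ethyl in place of phenyl on a saturated chain carbon, four bonds along the chain from an amide-type nitrogen. The place of the change reads the same for both pairs, so this is the same change on the other core. Going by the values given here, no measured step for it is readable, and there is no indication that the chain end sets where these compounds stand.

From compound 2 to compound 4 the step is expected to be a step that the limit leaves unreadable from compound 2 to compound 4, beside the unreadable earlier one, and that expectation rests on (the limit of > 2 h in this assay, at which 3 of the 3 values shown sit). Compound 4 is therefore estimated at 3 h, between 1.5 h and 6 h, most likely reported as a limit once more.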

Compound 4, half-life: > 2 h
Compound 4 ended at the assay's limit; the forecaster's own chance of this, stated with the estimate: 85%; the middle value is on the limit's open side.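

In this assay compound 4 gives > 2 h, a limit of the assay and not a number. No step can be read from compound 2 to compound 4, and the reason lies in where the values sit: the limit of > 2 h in this assay, at which 4 of the 4 values shown sit.

The compounds shown leave open how long any of the four lasts, and whether ethyl in place of phenyl or the difference between the two cores changes the half-life at all.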